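Pyrimidin-2-yl in Place of Pyrazin-2-yl on Compound 2

The source may report more compounds than this note shows. Statements on the series, on what has been measured and on what is new or still open speak of the compounds shown alone.

Going by the values given here, compound 2 `O=C(CCN1CCC(c2nc(-c3cnccn3)no2)CC1)N1CCC[C@H]1c1nc2cc(Cl)c(Cl)cc2[nH]1` holds the lowest of the two numbers measured so far in an assay on a cell-free system (plasma) for inhibition of lysosomal Pro-X carboxypeptidase (Mus musculus) (a lower number here means a stronger inhibitor, a higher number a weaker inhibitor), where compound 2 gives 435 nM. Among the compounds with values here, its only measured neighbour is compound 1 `O=C(CCN1CCC(c2cnccn2)CC1)N1CCC[C@H]1c1nc2cc(Cl)c(Cl)cc2[nH]1`, which in this assay gives 8000 nM. That single step, an 18-fold lower number from compound 1 to compound 2 (1.26 log units; beyond the scatter), was large. Compound 3 `O=C(CCN1CCC(c2nc(-c3ncccn3)no2)CC1)N1CCC[C@H]1c1nc2cc(Cl)c(Cl)cc2[nH]1` differs from compound 2 by pyrimidin-2-yl in place of pyrazin-2-yl on an aromatic carbon. Within the data shown here, no measured step bears directly on this change: the one step in hand concerned the group on the saturated ring carbon, a different place, and it cannot be read across. Since the same atoms are merely joined differently, compound 3 is expected to stay close to compound 2, and compound 3 is expected to show a step of a 1.1-fold higher number from compound 2 to compound 3 (0.06 log units; within the scatter), within the scatter. Compound 3 is therefore estimated at 500 nM in this assay, with a range from 150 nM to 1800 nM.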

Compound 3, half-maximal inhibitory concentration: 745 nM
Estimate against measurement, compound 3: 1.5-fold (0.17 log units) below; low and high end bracket the measured number.
By their numbers in this assay, from the lowest: compounds 2 and 3 (each within the scatter of the next); then compound 1.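

In this assay, a 1.7-fold higher number from compound 2 to compound 3 (0.23 log units; within the scatter) shows that on this aromatic carbon of the five-membered ring, pyrimidin-2-yl and pyrazin-2-yl cannot be told apart, so this rearrangement of the same atoms leaves the number within the scatter. The second step, an 11-fold lower number from compound 1 to compound 3 (1.03 log units; beyond the scatter), shows that the large drop seen earlier with the bigger group on the saturated ring carbon is not tied to pyrazin-2-yl and also appears with pyrimidin-2-yl. No measurement at hand accounts for either step.

The compounds shown leave open whether a phenyl or pyridin-2-yl group on this aromatic carbon would stay in the same range. They also leave open whether an amine or a carboxylic acid there would shift the number.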